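Replacing the aryl group of compound 1 with methoxy

The compounds below may be only part of what the source reports. "The series", "measured", "known", "first", "only" and "open" are said of these compounds alone.

Measured in an ADME assay on L1210/0 cells (Mus musculus) for cytotoxicity, with a stated time of 48 h (a lower number here means a stronger inhibitor, a higher number a weaker inhibitor), so far:
- compound 1 `Cc1ccc(-c2ncnc3c2ncn3C[C@@H]2C[C@H](CO)c3ccccc32)cc1` gives 15400 nM as a measured number
- compound 2 `O=c1[nH]c(=O)n(C[C@@H]2C[C@H](O)c3ccccc32)cc1Br` gives > 200000 nM as a limit of the assay and not a number
- compound 3 `O=C1OC(C(O)Cn2cc(F)c(=O)[nH]c2=O)C(OCc2ccccc2)=C1OCc1ccccc1` gives 140000 nM as a measured number

Of the two measured numbers, compound 1 holds the lower, and the gap to compound 3 lies beyond the scatter. Still unmeasured is compound 4 `COc1ncnc2c1ncn2C[C@@H]1C[C@H](CO)c2ccccc21` which keeps the core of compound 1 and has methoxy in place of 4-methylphenyl on an aromatic carbon with everything else unchanged.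

Going by the values given here, no measured step isolates this change, so the expectation is loose. Among the compounds with values here, a step to a higher number in this assay beyond the scatter is expected, since compound 1 at 15400 nM is the only measured compound carrying 4-methylphenyl and compound 3 without it reads 140000 nM in the same assay. The expected change is a 4.5-fold higher number from compound 1 to compound 4 (0.66 log units; beyond the scatter) toward weaker inhibition. For compound 4 the estimate is 70000 nM with an expected range from 25000 nM to 200000 nM in this assay.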

Compound 4, half-maximal inhibitory concentration: > 200000 nM
Compound 4: a limit, no number; the forecaster's own chance of this, stated with the estimate: 25%; middle value at least 2.8-fold (0.45 log units) away from the limit.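

Going by these compounds alone, this is the first step that isolates a single change: in this assay, methoxy in place of 4-methylphenyl on an aromatic carbon gives an at least 12-fold higher number from compound 1 to compound 4 (1.11 log units; beyond the scatter). With the rest of the structure unchanged, the read-out at this position therefore depends strongly on the group it carries, and the measured cytotoxicity of compound 1 does not survive this replacement. The true size of the step stays unknown because compound 4 gives only a limit of the assay and not a number: the limit of > 200000 nM in this assay, at which 2 of the 4 values shown sit.

The compounds shown leave open whether the aromatic ring itself matters or whether its methyl group contributes as well, a question that unsubstituted phenyl at this carbon would address. Also open, going by these compounds, is how an amine or a longer alkyl chain at this position would read.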